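Removing the phenolic hydroxy from an inactive glycoside ester

The source may report more compounds than this note shows. Statements on the series, on what has been measured and on what is new or still open speak of the compounds shown alone.

compound 1, `C/C=C1/[C@H](O[C@@H]2O[C@H](CO)[C@@H](O)[C@H](O)[C@H]2O)OC=C(C(=O)OC)[C@H]1CC(=O)OCCc1ccc(O)cc1`, > 20000 nM
compound 2, `C/C=C1/[C@H](O[C@@H]2O[C@H](COC(C)=O)[C@@H](OC(C)=O)[C@H](OC(C)=O)[C@H]2OC(C)=O)OC=C(C(=O)OC)[C@H]1CC(=O)OC`, > 15000 nM

In a functional assay on SK-BR-3 cells (Homo sapiens) for antiproliferative activity, read by MTT assay, with a stated time of 72 h (a higher number here means a weaker inhibitor, a lower number a stronger inhibitor), compound 1 returns only a limit, > 20000 nM, and no number. Compound 2 likewise gives a limit, > 15000 nM. Both measured compounds therefore sit at the edge of what this assay can report, and compound 1 stands with no measured potency at all. Going by the values given here, no pair of measured compounds differs in a single place, so no measured step is available to judge how a small change moves the value here.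

Compound 3, `C/C=C1/[C@H](O[C@@H]2O[C@H](CO)[C@@H](O)[C@H](O)[C@H]2O)OC=C(C(=O)OC)[C@H]1CC(=O)OCCc1ccccc1`, differs from compound 1 by hydrogen in place of hydroxy on an aromatic carbon. With both measured compounds at a limit, the expected step is a number no higher from compound 1 to compound 3 (the limit leaves the size open), none beyond the scatter. Compound 3 is thus estimated to give about 20000 nM, within the range 8000 nM to 60000 nM, and most likely once again only a limit rather than a number.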

Compound 3, half-maximal inhibitory concentration: 11000 nM
Estimate against measurement, compound 3: 1.8-fold (0.26 log units) above, within the range that was stated.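

Among the compounds shown, compound 3 alone gives a number rather than a limit in this assay, and it does so without the phenolic hydroxy. Going from 4-hydroxyphenyl to phenyl gives an at least 1.8-fold lower number from compound 1 to compound 3 (0.25 log units; that floor lies within the scatter), so this hydroxy is not required for a measured value to appear, although the change cannot be said to exceed the scatter. The true size of the step stays open because compound 1 gives a limit and not a number: the limit of > 20000 nM in this assay, at which 1 of the 3 values shown sits.

Only hydroxy and hydrogen are shown on this aromatic carbon, so what a methoxy or an amine there would do remains open, as does the effect of a longer chain than phenethyl. Compound 2 differs from compound 3 in more than one place and so offers no comparison.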